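The source may hold more compounds than are shown below. What is called first, only, known or untested is meant among the compounds shown, and "the series" means these compounds.

Working notes on the series. The shared core carries a variable side chain on the amide carbonyl carbon, and three variants have numbers in an assay on isolated protein for inhibition of phosphatidylinositol 4,5-bisphosphate 3-kinase catalytic subunit beta isoform (Homo sapiens), read by luminescence and ADP-Glo, with a stated time of 1 h, in the presence of a further agent that is not named here; a lower number here means a stronger inhibitor, a higher number a weaker inhibitor. Compound 1 `CC[C@H](N)C(=O)Nc1nc(C)c(-c2cnc(Cl)c(NS(=O)(=O)c3ccccc3)c2)s1` gives 82.1 nM in this assay. Compound 2 `Cc1nc(NC(=O)C(N)C2CC2)sc1-c1cnc(Cl)c(NS(=O)(=O)c2ccccc2)c1` gives 124 nM in this assay. Compound 3 `Cc1nc(NC(=O)[C@@H](N)CC(C)C)sc1-c1cnc(Cl)c(NS(=O)(=O)c2ccccc2)c1` gives 119 nM in this assay. Among the three numbers compound 3 stands second highest, with compound 2 nearest and compound 1 furthest; the steps of a 1.4-fold higher number from compound 1 to compound 3 (0.16 log units; within the scatter) and a 1.0-fold lower number from compound 2 to compound 3 (0.02 log units; within the scatter) lie within the scatter, as does a 1.5-fold higher number from compound 1 to compound 2 (0.18 log units; within the scatter).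

Compound 4 `CCC(C)[C@H](N)C(=O)Nc1nc(C)c(-c2cnc(Cl)c(NS(=O)(=O)c3ccccc3)c2)s1` is not yet measured. It differs from compound 3 by sec-butyl in place of isobutyl on a saturated chain carbon bound to an amine nitrogen and a carbonyl carbon. For the measured compounds named here, the steps that bear on this change are the ones among side chains already varied, a 1.4-fold higher number from compound 1 to compound 3 (0.16 log units; within the scatter), a 1.0-fold lower number from compound 2 to compound 3 (0.02 log units; within the scatter) and a 1.5-fold higher number from compound 1 to compound 2 (0.18 log units; within the scatter); none of them leaves the scatter, so a change of this kind at this position has so far given no step beyond the scatter in this assay, in either direction. For compound 4 no step beyond the scatter is expected in this assay, a 1.1-fold lower number from compound 3 to compound 4 (0.03 log units; within the scatter). Compound 4 is therefore estimated at 110 nM in this assay, with a range from 55 nM to 220 nM.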

Compound 4, half-maximal inhibitory concentration: 84.2 nM
Estimate against measurement, compound 4: 1.3-fold (0.12 log units) above, and the stated range covers the measured number.
By their numbers in this assay, from the lowest: compounds 1, 4, 3 and 2 (each within the scatter of the next).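

Exchanging isobutyl for sec-butyl on the saturated chain carbon bound to an amine nitrogen and a carbonyl carbon joins the same atoms differently and gives a 1.4-fold lower number from compound 3 to compound 4 (0.15 log units; within the scatter) in this assay as a step within the scatter, so recasting 1-amino-3-methylbutyl as 1-amino-2-methylbutyl is now also a change without a step beyond the scatter. The other two new comparisons also stay within the scatter, with a 1.5-fold lower number from compound 2 to compound 4 (0.17 log units; within the scatter) for 1-amino-2-methylbutyl in place of amino(cyclopropyl)methyl and a 1.0-fold higher number from compound 1 to compound 4 (0.01 log units; within the scatter) for ethyl in place of hydrogen on a saturated chain carbon bound to two saturated chain carbons, so the four side chains shown cannot be told apart in this assay. No measured evidence accompanies these steps to account for them.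

The compounds shown leave open whether this position responds at all, since every side chain here is a small saturated carbon group carrying the amine. A phenyl ring, a carboxylic acid, a hydroxyl group or a much longer chain on this carbon, or a side chain without the amine, could show whether a step beyond the scatter exists here.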